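This account rests on a few compounds, and the source may have more. Where it says the series, first, only, none or still open, it means among the compounds named here.

Measured compounds:
Compound 1, `O=C(O)c1ccccc1-c1ccc(CCc2ncc(Cc3ccccc3Cl)[nH]2)cc1`, gives 22 nM.
Compound 2, `CCC(C)(C)Cc1c[nH]c(CCc2ccc(-c3ccccc3C(=O)O)cc2)n1`, gives 9.6 nM.

Both were tested in an in vitro functional assay on cells for agonist activity at Bombesin receptor subtype-3 (Mus musculus), read by luminescence and calcium flux; a higher number here means that more compound is needed for the effect, a lower number that less compound is needed. Of the two numbers, compound 1 has the higher one; its nearest neighbour is compound 2, and the gap between them is beyond the usual scatter, so compound 2 needs less compound for the same effect than compound 1 does.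

The next compound, compound 3, `O=C(O)c1ccccc1-c1ccc(CCc2ncc(Cc3cccc(F)c3F)[nH]2)cc1`, has not yet been measured in this assay. It differs from compound 1 in a single place: 2,3-difluorophenyl in place of 2-chlorophenyl on a saturated chain carbon bound to an aromatic carbon. The rest of the shared core stays as it is.

Going by the values given here, no pair of measured compounds differing only at this spot is available, so the effect of swapping one halogenated ring for another here is unknown. The expectation is that the step from compound 1 to compound 3 is small, a 1.8-fold higher number from compound 1 to compound 3 (0.26 log units; within the scatter), and possibly no larger than the scatter. On that basis compound 3 is estimated at 40 nM in this assay, within a range of 12 nM to 130 nM.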

Compound 3, half-maximal effective concentration: 8 nM
For compound 3 the middle estimate is 5.0-fold (0.70 log units) above the measured one; measured number below the stated range.
By their numbers in this assay, from the lowest: compounds 3 and 2 (each within the scatter of the next); then compound 1.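

In this assay, exchanging 2-chlorophenyl for 2,3-difluorophenyl on a saturated chain carbon bound to an aromatic carbon gives a 2.8-fold lower number from compound 1 to compound 3 (0.44 log units; beyond the scatter) and so shows that this ring is not a passive part of the molecule. With the shared core unchanged, replacing one halogenated ring with another moves the result beyond the scatter, towards less compound being needed, although the step is only modest in size. No accompanying measurement bears on why this swap lowers the number.

This single pair cannot separate the removal of the chlorine from the addition of the two fluorines, nor show how much depends on where those fluorines sit on the ring. Phenyl rings carrying a single fluorine, a methoxy group or a nitrile at this spot, or an unsubstituted phenyl ring, would be needed to tell whether the lower number belongs to this one fluorine arrangement or extends to other ring substituents.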